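A few compounds are considered here, and "the series" means these few. Any claim that something is new, unique, unknown or untested is made for them only; others in the source may bear on it.

Compound 1 `O=C1O[C@H]([C@@H](O)Cn2cc(-c3cc(F)cc(F)c3)nn2)C(OCc2ccccc2)=C1OCc1ccccc1` is the starting point. In a functional assay on A549 cells (Homo sapiens) for antiproliferative activity, read by MTT assay, with a stated time of 72 h (a higher number here means a weaker inhibitor, a lower number a stronger inhibitor), compound 1 gives 41200 nM, the only result that comes as a number here. Compound 2 `CC(C)(C)OC(=O)N1CCN(C(=S)SCc2cn(C[C@H](O)[C@H]3OC(=O)C(OCc4ccccc4)=C3OCc3ccccc3)nn2)CC1` returns only a limit in this assay, > 100000 nM. Compound 3 `COc1ccccc1-c1cn(C/C=C2\OC(=O)C(OCc3ccccc3)=C2OCc2ccccc2)nn1` likewise gives only a limit, > 100000 nM. Compound 1 therefore stands apart from its two companions because of the limit of > 100000 nM in this assay, at which 2 of the 3 values shown sit, while compound 1 alone sits below that edge. Compound 4 `O=C1O[C@H]([C@@H](O)Cn2cc(CNS(=O)(=O)c3ccc(Cl)cc3)nn2)C(OCc2ccccc2)=C1OCc1ccccc1` is not yet measured; the change from compound 1 is (((4-chlorophenyl)sulfonyl)amino)methyl in place of 3,5-difluorophenyl on an aromatic carbon. Among the compounds with values here, no measured pair shows what such a change does. The step of a 1.2-fold higher number from compound 1 to compound 4 (0.08 log units; within the scatter) is expected to stay within the usual scatter, as nothing here points either way. Compound 4 is thus estimated at 50000 nM, between 12000 nM and 150000 nM.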

Compound 4, half-maximal inhibitory concentration: 2870 nM
Estimate against measurement, compound 4: 17-fold (1.24 log units) above; the whole stated range lies above it.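

On this aromatic carbon of the five-membered ring, (((4-chlorophenyl)sulfonyl)amino)methyl in place of 3,5-difluorophenyl gives a 14-fold lower number from compound 1 to compound 4 (1.16 log units; beyond the scatter) in this assay. The group on this carbon therefore clearly matters to the read-out, and an aromatic ring set directly on the carbon is not required for the lower number. No measurement shown here says which part of the new group accounts for the change.

On these data alone, whether the chlorine, the sulfonyl group or the amino hydrogen is needed stays open. So does what a simple amine, a carboxylic acid or a longer chain on this carbon would do.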